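Branching the Ketone Chain in a Glutamate Receptor Modulator Series

The source may hold more compounds than are shown below. What is called first, only, known or untested is meant among the compounds shown, and "the series" means these compounds.

The compounds here were tested in an assay on HEK293 cells for positive allosteric modulation of metabotropic glutamate receptor 3 (Rattus norvegicus), read by thallium flux, with a stated time of 2.5 min; on this read-out lower numbers stand for smaller maximal responses and higher numbers for larger maximal responses. Compound 1 `CCCC(=O)c1ccc(OCCCCOc2cccc(C(=O)O)c2C)c(C)c1O` carries a propyl group on its carbonyl carbon and reaches 53% in this assay. Compound 2 `Cc1c(OCCCCOc2ccc(C(=O)C(C)C)c(O)c2C)cccc1C(=O)O` differs from compound 1 by a single change, (isopropyl in place of propyl on a carbonyl carbon), and in this assay compound 2 reaches 27.1%. The step of a number 25.9 percentage points lower from compound 1 to compound 2 (beyond the scatter) therefore points toward a smaller maximal response when the chain on the carbonyl carbon is branched.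

Compound 3 `CCCC(=O)c1ccc(OCCCCOc2ccc(C(=O)O)cc2C)c(C)c1O` shares the propyl ketone of compound 1 but has a different core; the difference between the two cores is not broken down here. In this assay compound 3 reaches 40.5%, which places it between compound 1 and compound 2.

Compound 4 `Cc1cc(C(=O)O)ccc1OCCCCOc1ccc(C(=O)C(C)C)c(O)c1C` has not yet been measured. It stands to compound 3 exactly as compound 2 stands to compound 1: the change is isopropyl in place of propyl on a carbonyl carbon, at a place described in the same words as before, so it is the same change made on the second core. Whether the drop seen once will repeat on a different core is the open question, and the estimate rests on that single example.

Compound 4 is expected to follow the earlier step, giving an estimated a number 22.5 percentage points lower from compound 3 to compound 4 (beyond the scatter) in this assay, because the change from compound 1 to compound 2 gave a number 25.9 percentage points lower from compound 1 to compound 2 (beyond the scatter). Compound 4 is therefore estimated to reach about 18%, with a plausible range from 8% to 32%.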

Compound 4, largest response reached (reported as percent of maximum), in percent of the reference or control that the assay uses: 25.2%
The estimate for compound 4 lay 7.2 percentage points below the measured number, and the stated range covers the measured number.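

Replacing propyl with isopropyl on the carbonyl carbon of the second core gives a number 15.3 percentage points lower from compound 3 to compound 4 (beyond the scatter) in this assay, so the fall seen on the first core appears here as well. Set side by side, the two steps point the same way and cannot be told apart in size: the same change on two cores in this assay, a number 25.9 percentage points lower (beyond the scatter) from compound 1 to compound 2 and a number 15.3 percentage points lower (beyond the scatter) from compound 3 to compound 4, 10.6 percentage points apart, within the scatter of two such steps. The change therefore carries over between these two cores in this one read-out, but two pairs are a small sample: they do not show that it would hold on any other core or in any other assay, and they do not explain why the maximal response falls.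

Only propyl and isopropyl appear on the carbonyl carbon in the compounds shown, so it remains open how a longer chain such as pentyl, a more heavily branched group such as tert-butyl, or a small ring such as cyclopropyl would behave there. Also open, as far as these compounds go, is whether the same step would appear on a core that carries an amide or a tetrazole where these compounds have their carboxylic acid.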